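The compounds below may be only part of what the source reports. "The series", "measured", "known", "first", "only" and "open" are said of these compounds alone.

In a functional assay on HeLa cells (Homo sapiens) for cytotoxicity, read by MTT assay, with a stated time of 48 h (on this read-out higher numbers stand for weaker inhibition and lower numbers for stronger inhibition), compound 1 (`COc1ccc(-c2nc3ccccn3c2C(=O)/C=C\Nc2cc(OC)cc(OC)c2)cc1`) gives 4570 nM and compound 2 (`COc1ccc(-c2nc3ccccn3c2C(=O)/C=C\Nc2ccc3cc[nH]c3c2)cc1`) gives 15300 nM as the higher of the two numbers. For the measured compounds named here, the only measured step is a 3.3-fold higher number from compound 1 to compound 2 (0.52 log units; beyond the scatter) and it is modest, so it offers limited guidance. Compound 3 (`COc1ccc(-c2nc3ccccn3c2C(=O)/C=C\Nc2cnc3ccccc3c2)cc1`) has quinolin-3-yl in place of 1H-indol-6-yl on an amine nitrogen with the core unchanged. A modest move towards a lower number in this assay is expected, of similar or smaller size than that step, and it is estimated as a 1.9-fold lower number from compound 2 to compound 3 (0.28 log units; within the scatter) for this change. For compound 3 the estimate is 8000 nM with an expected range from 2500 nM to 25000 nM on this read-out.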

Compound 3, half-maximal inhibitory concentration: 9440 nM
Beside the measured number, compound 3's estimate is 1.2-fold (0.07 log units) below it, within the range that was stated.
By their numbers in this assay, from the lowest: compound 1; then compounds 3 and 2 (each within the scatter of the next).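

In this assay the exchange of 1H-indol-6-yl for quinolin-3-yl on the amine nitrogen gives a 1.6-fold lower number from compound 2 to compound 3 (0.21 log units; within the scatter) as a hydrogen-bond donor leaves and a hydrogen-bond acceptor enters, so this change in counts does not move the number beyond the scatter. Set against 3,5-dimethoxyphenyl, quinolin-3-yl gives a 2.1-fold higher number from compound 1 to compound 3 (0.32 log units; beyond the scatter) and compound 1 thus keeps the lowest number of the three. Nothing available here explains these differences.

Open, as far as these compounds go, is whether an unsubstituted phenyl, a phenyl with a single methoxy group or a cyclohexyl on this nitrogen would match compound 1 or fall below it.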